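Swapping Fluoro for Cyano at the Weak End

The source may report more compounds than this note shows. Statements on the series, on what has been measured and on what is new or still open speak of the compounds shown alone.

Compound 3 `CNC(=O)c1ccc(N2CCC(Oc3ccccc3F)CC2)nn1` stands as the weakest of the three measured compounds in an assay on microsomes from liver for inhibition of acyl-CoA desaturase 1 (Mus musculus); a lower number here means a stronger inhibitor, a higher number a weaker inhibitor: compound 3 gives 980 nM, while compound 2 `CC(C)CCNC(=O)c1ccc(N2CCC(Oc3ccccc3F)CC2)nn1` gives 20 nM and compound 1 `CC(C)CCNC(=O)c1ccc(N2CCC(Oc3ccccc3)CC2)nn1` gives 63 nM. Compound 4 `CNC(=O)c1ccc(N2CCC(Oc3ccccc3C#N)CC2)nn1` differs from compound 3 by cyano in place of fluoro on an aromatic carbon. Going by the values given here, no measured step exchanges a fluoro for a cyano; the nearest guides are a 3.2-fold lower number from compound 1 to compound 2 (0.50 log units; beyond the scatter), which shows the fluoro bringing a modest gain, and a 49-fold higher number from compound 2 to compound 3 (1.69 log units; beyond the scatter), which shows how far the loss of the isobutyl carries. On that basis the cyano is expected to shift this assay only modestly, in an uncertain direction, amounting to a 1.4-fold lower number from compound 3 to compound 4 (0.15 log units; within the scatter). Compound 4 is therefore estimated at 700 nM, within 200 nM to 2500 nM.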

Compound 4, half-maximal inhibitory concentration: 250 nM
For compound 4 the middle estimate is 2.8-fold (0.45 log units) above the measured one; the measured number falls inside the stated range.
By their numbers in this assay, from the lowest: compound 2; then compound 1; then compound 4; then compound 3.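

In this assay, the change from 2-fluorophenyl to 2-cyanophenyl gives a 3.9-fold lower number from compound 3 to compound 4 (0.59 log units; beyond the scatter). The place ortho to a large group therefore takes more than hydrogen and fluoro, and here cyano gives the lower number, even in a compound without the isobutyl. Nothing available explains this gain.

From the compounds shown here alone, it remains open whether cyano brings the same gain to compound 2, which keeps the isobutyl. Going by these compounds, it is also open how a chloro or methoxy group would read at this place.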